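Ring Size Change on the Pyrrolidine Nitrogen of a Substance-P Antagonist

This account rests on a few compounds, and the source may have more. Where it says the series, first, only, none or still open, it means among the compounds named here.

Compound 1 `CCNC(=O)N1C[C@@H](O[C@H](C)c2cc(C(F)(F)F)cc(C(F)(F)F)c2)[C@H](c2ccc(F)cc2)C1`: 0.1 nM
Compound 2 `C[C@@H](O[C@@H]1CN(C2=CC(=O)CC2)C[C@H]1c1ccccc1)c1cc(C(F)(F)F)cc(C(F)(F)F)c1`: 0.07 nM

In an assay on CHO cells for displacement of a labelled ligand from Substance-P receptor (Homo sapiens) (a lower number here means a stronger inhibitor, a higher number a weaker inhibitor), compound 2 gives 0.07 nM, the lower of the two numbers, but its gap to compound 1 lies within the scatter, so the two cannot be told apart. Compound 3 `C[C@@H](O[C@@H]1CN(C2=CC(=O)CC(C)(C)C2)C[C@H]1c1ccccc1)c1cc(C(F)(F)F)cc(C(F)(F)F)c1` is not yet measured. It differs from compound 2 by 5,5-dimethyl-3-oxocyclohex-1-en-1-yl in place of 3-oxocyclopent-1-en-1-yl on an amine nitrogen in a ring. For the measured compounds named here, with no measured step of this kind to lean on, the change is expected to move the number little, if at all beyond the scatter, so the step from compound 2 to compound 3 in this assay is estimated at a 2.1-fold higher number from compound 2 to compound 3 (0.33 log units; beyond the scatter). Compound 3 is therefore expected to give about 0.15 nM, most likely between 0.04 nM and 0.6 nM.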

Compound 3, half-maximal inhibitory concentration: 0.13 nM
Compound 3: the middle estimate sits 1.2-fold (0.06 log units) above what was measured, and the stated range covers the measured number.
By their numbers in this assay, from the lowest: compounds 2, 1 and 3 (each within the scatter of the next).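

Replacing 3-oxocyclopent-1-en-1-yl with 5,5-dimethyl-3-oxocyclohex-1-en-1-yl on the amine nitrogen in a ring gives a 1.9-fold higher number from compound 2 to compound 3 (0.27 log units; within the scatter) in this assay. The two compounds cannot be told apart, so this position accepts the six-membered ring with its two methyl groups without a change that stands clear of the scatter. Nothing here explains this result.

Ring size and the two methyl groups changed together, and the plain 3-oxocyclohex-1-en-1-yl group would separate them. From the compounds shown here alone, how a carboxylic acid on this nitrogen would read in this assay also stays open.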